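Replacing pyridin-2-yl on the carbonyl: compound 1 to compound 4

The source may report more compounds than this note shows. Statements on the series, on what has been measured and on what is new or still open speak of the compounds shown alone.

In a functional assay on MCF7 cells (Homo sapiens) for antiproliferative activity, read by MTT assay, with a stated time of 24 h (a higher number here means a weaker inhibitor, a lower number a stronger inhibitor), compound 1 (`COC(=O)c1scc(-c2ccc(NC(=O)c3ccccn3)cc2)c1OC`) gives 19200 nM and lies within the scatter of compound 2 (`COC(=O)c1scc(-c2ccc(NC(=O)c3ccc(C(F)(F)F)cc3Br)cc2)c1OC`), which gives 22400 nM in the same read-out. Compound 3 (`COC(=O)c1scc(-c2ccc(NC(=O)c3cccc(OC(F)(F)F)c3)cc2)c1OC`) gives 2220 nM and so stands beyond the scatter on the stronger side of compound 1.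

Compound 4 (`COC(=O)c1scc(-c2ccc(NC(=O)c3cc(I)ccc3F)cc2)c1OC`) keeps the core of compound 1 and takes 2-fluoro-5-iodophenyl in place of pyridin-2-yl on a carbonyl carbon. For the measured compounds named here, no measured pair isolates this change. Compound 2 (22400 nM) and compound 3 (2220 nM) also lack the pyridin-2-yl, yet their values lie far apart, so its removal alone gives no firm direction.

A modest move toward a lower number in this assay is expected, although a result within the scatter of compound 1 remains possible. The step expected here is a 2.4-fold lower number from compound 1 to compound 4 (0.38 log units; beyond the scatter) as a working figure. Compound 4 is estimated at 8000 nM with 2500 nM to 22000 nM as the expected range.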

Compound 4, half-maximal inhibitory concentration: 22500 nM
Compound 4: the middle estimate sits 2.8-fold (0.45 log units) below what was measured; measured number outside the range, above it.
By their numbers in this assay, from the lowest: compound 3; then compounds 1, 2 and 4 (each within the scatter of the next).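

In this assay, the first step read at this position, 2-fluoro-5-iodophenyl in place of pyridin-2-yl on a carbonyl carbon, gives a 1.2-fold higher number from compound 1 to compound 4 (0.07 log units; within the scatter) and so stays within the scatter, even though the ring nitrogen leaves and fluorine and iodine enter. A carbon-only aromatic ring on the carbonyl carbon therefore does not by itself bring the number down to that of compound 3 (2220 nM), so having such a ring in place of pyridin-2-yl is not enough. No measurement at hand accounts for the size of this step.

The compounds shown do not separate the contribution of the fluorine from that of the iodine. From the compounds shown here alone, how an amine such as morpholine, or a carboxylic acid, on the ring at this position would read remains open.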